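Urea aryl swap: methoxy in place of methyl

A few compounds are considered here, and "the series" means these few. Any claim that something is new, unique, unknown or untested is made for them only; others in the source may bear on it.

Measured compounds:
- Compound 1 `O=C(Nc1ccccc1OC(F)(F)F)N[C@H]1CC[C@H](Oc2ccc(F)cc2)CC1`; in a functional assay on CRL2813 cells (Homo sapiens) for cytotoxicity, read by sulforhodamine B assay, with a stated time of 5 days (on this read-out lower numbers stand for stronger inhibition and higher numbers for weaker inhibition), compound 1 gives > 20000 nM.
- Compound 2 `COc1ccc(NC(=O)N[C@H]2CC[C@H](Oc3ccc(F)cc3)CC2)cc1`; in this assay compound 2 gives > 20000 nM.

The value of compound 2 is a limit of the assay, not a number, so compound 2 stands at the floor of what the numbers can show. The value of compound 1 is likewise a limit. For the measured compounds named here, the whole picture so far is the limit of > 20000 nM in this assay, at which 2 of the 2 values shown sit, and no step between measured compounds can be read from it.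

Compound 3 `Cc1ccccc1NC(=O)N[C@H]1CC[C@H](Oc2ccc(F)cc2)CC1` is not yet measured. It differs from compound 2 by 2-methylphenyl in place of 4-methoxyphenyl on an amide-type nitrogen. Going by the values given here, with no measured step to go on, no change beyond the scatter is expected in this assay, and the expected step that the limit leaves unreadable from compound 2 to compound 3 reflects this. Compound 3 is therefore expected at 25000 nM, most likely reported again only as a limit, with a range from 8000 nM to 80000 nM.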

Compound 3, half-maximal inhibitory concentration: > 20000 nM
Compound 3: only a limit was reported (the forecaster's own chance of this, stated with the estimate: 75%); the middle value does not contradict the limit.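

Compound 3 joins compound 1 and compound 2 as a limit, so neither step to compound 3 can be read: the limit of > 20000 nM in this assay, at which 3 of the 3 values shown sit. The compounds shown leave open whether any aryl group on this urea and the shared core gives a measurable value in this assay.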